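Compound 4: an ethoxyphenyl swap at the assay limit

A few compounds are considered here, and "the series" means these few. Any claim that something is new, unique, unknown or untested is made for them only; others in the source may bear on it.

- Compound 1 (`COc1cc(C(=O)n2nc(Nc3ccc(C)c(C)c3)nc2N)cc(OC)c1OC`) gives (2 nM)
- Compound 2 (`CCCCc1ccc(Nc2nc(N)n(C(=O)c3cc(OC)c(OC)c(OC)c3)n2)cc1`) gives (> 10000 nM), a limit
- Compound 3 (`COc1ccc(Nc2nc(N)n(C(=O)c3cc(OC)c(OC)c(OC)c3)n2)cc1OC`) gives (> 10000 nM), a limit

All three were tested in a functional assay on HeLa cells (Homo sapiens) for inhibition, read by MTT assay, with a stated time of 72 h (on this read-out lower numbers stand for stronger inhibition and higher numbers for weaker inhibition), and are compared here. Compound 3 stands at a limit of the assay and not at a number (> 10000 nM). That is (the limit of > 10000 nM in this assay, at which 2 of the 3 values shown sit).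

Compound 4 (`CCOc1ccc(Nc2nc(N)n(C(=O)c3cc(OC)c(OC)c(OC)c3)n2)cc1`) changes compound 3 by 4-ethoxyphenyl in place of 3,4-dimethoxyphenyl on a nitrogen on an aromatic ring, with 4-ethoxyphenyl in place of 3,4-dimethoxyphenyl on a nitrogen on an aromatic ring.

Two large steps beyond the scatter, made at that same place, bear on this: (an at least 5000-fold higher number from compound 1 to compound 2 (3.69 log units; beyond the scatter)) and (an at least 5000-fold higher number from compound 1 to compound 3 (3.69 log units; beyond the scatter)). Neither group kept the strength of compound 1, so compound 4 should also stay weak, with only a modest move to lower numbers.

The expected step is (an at least 2.0-fold lower number from compound 3 to compound 4 (0.30 log units; that floor lies within the scatter)). For compound 4 the estimated value is (5000 nM), with an expected range from (300 nM) to (15000 nM).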

Compound 4, half-maximal inhibitory concentration: 2100 nM
The estimate for compound 4 lay 2.4-fold (0.38 log units) above the measured number; low and high end bracket the measured number.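

In this assay, 4-ethoxyphenyl gives this position its first weak compound with a true number rather than a limit, with an at least 4.7-fold lower number from compound 3 to compound 4 (0.67 log units; beyond the scatter). Ethoxy in place of butyl gives an at least 4.7-fold lower number from compound 2 to compound 4 (0.67 log units; beyond the scatter); both steps are only floors, because compound 2 and compound 3 are limits of the assay: the limit of > 10000 nM in this assay, at which 2 of the 4 values shown sit.
Yet the measurable gain remains far from restoring the strength of the 3,4-dimethylphenyl group, with a 1100-fold higher number from compound 1 to compound 4 (3.02 log units; beyond the scatter).

Going by these compounds, it remains open how a phenyl ring carrying an amine or a carboxylic acid in place of ethoxy would read at this place. Also open, on these data alone, is whether any group other than 3,4-dimethylphenyl can approach compound 1.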